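Swapping a bromine for a cyanophenyl on the strongest inhibitor

The compounds below may be only part of what the source reports. "The series", "measured", "known", "first", "only" and "open" are said of these compounds alone.

Of the compounds shown here, three have been measured in an assay on isolated protein for inhibition of N-acylethanolamine-hydrolyzing acid amidase (Homo sapiens), read by fluorescence, with a stated time of 90 min; a lower number here means a stronger inhibitor, a higher number a weaker inhibitor. Compound 1 `COc1ncccc1-c1ccc(COC2CN(C#N)C2)cc1` gives 5.8 nM, compound 2 `COc1cccc(-c2ccc(COC3CN(C#N)C3)c(OC)c2)c1` gives 2.8 nM, and compound 3 `N#CN1CC(OCc2ccc(Oc3ccccc3)cc2Br)C1` gives 1.03 nM, the lowest number of the three, with both other compounds standing beyond the scatter above it. Compound 4 `N#Cc1ccc(-c2cc(Oc3ccccc3)ccc2COC2CN(C#N)C2)cc1` is not yet measured. It differs from compound 3 in one place: 4-cyanophenyl in place of bromo on an aromatic carbon. Among the measured compounds shown here, no pair of measured compounds differs in exactly one place, so no measured step guides this change directly. Compounds 1 and 2 show that a second aromatic ring on the shared core is compatible with strong inhibition. A small step in this assay is expected, possibly a mild weakening, of the size a 1.7-fold higher number from compound 3 to compound 4 (0.24 log units; within the scatter). Compound 4 is therefore estimated at 1.8 nM, within 0.5 nM to 6 nM.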

Compound 4, half-maximal inhibitory concentration: 2.5 nM
The estimate for compound 4 lay 1.4-fold (0.14 log units) below the measured number; measured number inside the range.
By their numbers in this assay, from the lowest: compound 3; then compounds 4 and 2 (each within the scatter of the next); then compound 1.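

In this assay, 4-cyanophenyl in place of bromo gives a 2.4-fold higher number from compound 3 to compound 4 (0.39 log units; beyond the scatter), a modest weakening that lies beyond the scatter. This aromatic carbon therefore tolerates a group of 8 heavy atoms, including a carbon-only aromatic ring and a nitrile, where bromo had 1, and inhibition stays strong. No measurement shown here accounts for the weakening.

The compounds shown leave open how an amine, a carboxylic acid or a longer chain would fare on this same carbon. They also leave open whether a phenyl ring without the nitrile would give a similar number.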